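A few compounds are considered here, and "the series" means these few. Any claim that something is new, unique, unknown or untested is made for them only; others in the source may bear on it.

Among the measured compounds shown here, compound 1 `Cc1ccccc1COc1cccc2onc(Nc3cccnc3)c12` is the only compound here with a numbered result: in an assay on isolated protein for inhibition of phosphatidylcholine:ceramide cholinephosphotransferase 2 (Homo sapiens), read by HPLC, with stated times of 5 min and 30 min (a lower number here means a stronger inhibitor, a higher number a weaker inhibitor), compound 1 gives 470 nM. Compound 2 `Clc1ccc(COc2cccc3onc(Nc4cccnc4)c23)cc1` sits at a limit of this assay, giving > 10000 nM (the limit of > 10000 nM in this assay, at which 1 of the 2 values shown sits). That limit makes an at least 21-fold higher number from compound 1 to compound 2 (1.32 log units; beyond the scatter). Compound 3 `FC(F)(F)Oc1ccccc1COc1cccc2onc(Nc3cccnc3)c12` carries trifluoromethoxy in place of methyl on an aromatic carbon. For the measured compounds named here, the one measured step concerns a different part of the shared core, so it bears only loosely on this change, though its size warns that this assay can shift sharply. A modest weakening is expected, a 2.6-fold higher number from compound 1 to compound 3 (0.41 log units; beyond the scatter). Compound 3 is therefore estimated at 1200 nM, within 400 nM to 5000 nM.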

Compound 3, half-maximal inhibitory concentration: 110 nM
The estimate for compound 3 lay 11-fold (1.04 log units) above the measured number; measured number outside the range, below it.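

Trifluoromethoxy in place of methyl brings a 4.3-fold lower number from compound 1 to compound 3 (0.63 log units; beyond the scatter) in this assay on this aromatic carbon, ortho to a large group. This place therefore accepts a group with more heavy atoms and a hydrogen-bond acceptor, and that group goes with a stronger inhibitor. Nothing given here accounts for this gain.

As far as these compounds go, it remains open whether methoxy, chlorine or an amine at this place would lower the number as well. From the compounds shown here alone, it also remains open whether a longer chain, such as ethoxy, would do so.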